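Acetophenone ethers at the leukotriene B4 receptor: carboxy to tetrazolyl

This account rests on a few compounds, and the source may have more. Where it says the series, first, only, none or still open, it means among the compounds named here.

Measured so far in an assay on isolated protein for inhibition of leukotriene B4 receptor 1 (Homo sapiens), tested at 10 uM; a lower number here means less inhibition, a higher number more inhibition at the concentration tested (going by the name of the read-out):
Compound 1 `CCc1cc(C(C)=O)c(O)cc1OCCCCCCC(C)(C)C#N` gives 65% in this assay.
Compound 2 `CCc1cc(C(C)=O)c(O)cc1OCCCCCCCC(C)(C)C#N` gives 66% in this assay.
Compound 3 `CCc1cc(C(C)=O)c(O)cc1OCCCCCC(C)(C)C(=O)O` gives 104% in this assay.

Compound 3 stands highest of the three; its steps to the other two are both beyond the scatter, so its number in this assay is the highest measured here. Compounds 1 and 2 lie within the scatter of each other, as a number 1 percentage points higher from compound 1 to compound 2 (within the scatter) shows, so no order between them is claimed.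

Compound 4 `CCc1cc(C(C)=O)c(O)cc1OCCCCCC(C)(C)c1nnn(C)n1` differs from compound 3 in one place: 2-methyl-2H-tetrazol-5-yl in place of carboxy on a saturated chain carbon bound to three saturated chain carbons

Going by the values given here, no measured step shows this replacement. The steps that touch the same end of the chain are a number 39 percentage points higher from compound 1 to compound 3 (beyond the scatter) and a number 38 percentage points higher from compound 2 to compound 3 (beyond the scatter), both large, both pointing to the carboxy compound. The new group is neither a nitrile nor a carboxy, so the direction can only be guessed from the fact that every departure from carboxy seen so far has been a large drop. A drop is therefore expected, with wide uncertainty. For compound 4 the expected value is 75%, between 45% and 105%. This amounts to an expected a number 29 percentage points lower from compound 3 to compound 4 (beyond the scatter).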

Compound 4, a percentage reported as inhibition, at one concentration (the size of the read-out at that concentration, not a potency): 95%
Estimate against measurement, compound 4: 20 percentage points below; measured number inside the range.
By their numbers in this assay, from the lowest: compounds 1 and 2 (each within the scatter of the next); then compounds 4 and 3 (each within the scatter of the next).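

In this assay, 2-methyl-2H-tetrazol-5-yl can stand in place of carboxy on this saturated chain carbon bound to three saturated chain carbons, with a number 9 percentage points lower from compound 3 to compound 4 (within the scatter), so among these compounds a number in this range does not depend on carboxy or on its hydrogen-bond donor. The nitrile compounds remain apart from the tetrazole, with a number 29 percentage points higher from compound 2 to compound 4 (beyond the scatter) and a number 30 percentage points higher from compound 1 to compound 4 (beyond the scatter), although these are modest steps and the chain differs along with the end group. Nothing available explains the effect of this replacement.

Open, as far as these compounds go, is whether 1H-tetrazol-5-yl, with its ring hydrogen, or a primary amide at this place would give a similar number, and whether a longer chain would keep it. A single test concentration also leaves the potencies of compound 3 and compound 4 unresolved.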